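Aromatic side-group exchange in a weakly antiproliferative pair

A few compounds are considered here, and "the series" means these few. Any claim that something is new, unique, unknown or untested is made for them only; others in the source may bear on it.

Within the data shown here, in a functional assay on HeLa cells (Homo sapiens) for antiproliferative activity, read by MTT assay, with a stated time of 72 h (on this read-out higher numbers stand for weaker inhibition and lower numbers for stronger inhibition), compound 1 `O=C1NC(O)(CCn2cnc3cncc(Br)c32)C(OCc2ccccc2)=C1OCc1ccccc1` gives 77000 nM, the only finite number among the two measured compounds, and a weak one. Compound 2 `O=C1O/C(=C\Cn2cnc3ccnc(Cl)c32)C(OCc2ccccc2)=C1OCc1ccccc1` returns in this assay only a limit of the assay, > 100000 nM. That limit is described by the limit of > 100000 nM in this assay, at which 1 of the 2 values shown sits. Compound 1 therefore stands alone as a measured value in this assay. Compound 3 `Nc1nc(F)c(Cl)c2c1ncn2CCC1(O)NC(=O)C(OCc2ccccc2)=C1OCc1ccccc1` differs from compound 1 by a group of 12 heavy atoms (6 carbon, 4 nitrogen, 1 fluorine, 1 chlorine; one five-membered aromatic ring with 2 hetero atoms, one six-membered aromatic ring with 1 hetero atom) in place of a group of 10 heavy atoms (6 carbon, 3 nitrogen, 1 bromine; one five-membered aromatic ring with 2 hetero atoms, one six-membered aromatic ring with 1 hetero atom), on a saturated chain carbon, two bonds along the chain from a saturated ring carbon. Among the measured compounds shown here, no step between measured compounds differing in one place is available, so the size of this change in this assay cannot be read from the data. Given compound 1 at 77000 nM, the expectation is a step of no more than the scatter, in either direction. Compound 3 is expected at 80000 nM, with a range of 30000 nM to 160000 nM. The step from compound 1 to compound 3 is thus estimated at a 1.0-fold higher number from compound 1 to compound 3 (0.02 log units; within the scatter).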

Compound 3, half-maximal inhibitory concentration: 39000 nM
Compound 3: the middle estimate sits 2.1-fold (0.31 log units) above what was measured; the measured number falls inside the stated range.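

In this assay, among these compounds, the exchange on a saturated chain carbon, two bonds along the chain from a saturated ring carbon, gives the first readable step: a 2.0-fold lower number from compound 1 to compound 3 (0.30 log units; within the scatter). At this place, the group of 12 heavy atoms, with 1 hydrogen-bond donor, and the group of 10 heavy atoms, with 0 hydrogen-bond donors, therefore cannot be told apart on this read-out, and both compounds keep finite values. No measurement shown bears on what lies behind this step.

Whether any change at this place can give a step beyond the scatter remains open, since the single step shown stays within it. A carboxylic acid in place of the entering group, or a longer chain carrying it, would test this on the shared core.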